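Carbamate Swap from Benzyl to Tert-Butyl

The source may hold more compounds than are shown below. What is called first, only, known or untested is meant among the compounds shown, and "the series" means these compounds.

Compound 3 `COC(=O)CCCCC[C@H](NC(=O)OCc1ccccc1)C(=O)NC1CCCC1` gives 65% in an assay on isolated protein for inhibition of protein deacetylase HDAC6 (Homo sapiens), read by fluorescence, tested at 1 uM (on this read-out lower numbers stand for less inhibition and higher numbers for more inhibition at the one concentration tested (going by the name of the read-out)), the highest of the three measured values, and stands beyond the scatter above both others: compound 1 `CC(C)(C)OC(=O)N[C@@H](CCCCS)C(=O)NC1CCCC1` gives 50% and compound 2 `COC(=O)CCCC[C@H](NC(=O)OC(C)(C)C)C(=O)NC1CCCC1` gives 40%. Compound 4 `COC(=O)CCCCC[C@H](NC(=O)OC(C)(C)C)C(=O)NC1CCCC1` differs from compound 3 by tert-butyl in place of benzyl on an oxygen next to a carbonyl group. Among the compounds with values here, no measured step touches this group. Within the data shown here, the only measured step, a number 10 percentage points lower from compound 1 to compound 2 (within the scatter), concerns another part of the molecule. Compound 2 and compound 3 differ in two places at once, so their values alone cannot be ascribed to the carbamate group. Compound 4 is therefore expected to give 50% in this assay, with a range from 30% to 70%. The expected step is thus a number 15 percentage points lower from compound 3 to compound 4 (beyond the scatter).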

Compound 4, a percentage reported as inhibition, at one concentration (the size of the read-out at that concentration, not a potency): 60%
Beside the measured number, compound 4's estimate is 10 percentage points below it; the measured number falls inside the stated range.
By their numbers in this assay, from the lowest: compounds 2, 1, 4 and 3 (each within the scatter of the next, the first and the last beyond it).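

In this assay, tert-butyl in place of benzyl on an oxygen next to a carbonyl group gives a number 5 percentage points lower from compound 3 to compound 4 (within the scatter) and so leaves the read-out within the scatter, even though the aromatic ring goes. On a saturated chain carbon, (methoxycarbonyl)methyl in place of methoxycarbonyl gives a number 20 percentage points higher from compound 2 to compound 4 (beyond the scatter) and in place of sulfanyl gives a number 10 percentage points higher from compound 1 to compound 4 (within the scatter), so only the first of these two changes moves the read-out beyond the scatter. No evidence is available to explain these steps.

On these data alone, what a carboxylic acid or a hydroxamic acid would give in place of the methoxycarbonyl remains open, as does what a free amine would give in place of the carbamate.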